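A few compounds are considered here, and "the series" means these few. Any claim that something is new, unique, unknown or untested is made for them only; others in the source may bear on it.

In a functional assay on CCRF-CEM cells (Homo sapiens) for antiproliferative activity (a lower number here means a stronger inhibitor, a higher number a weaker inhibitor), compound 1 (`COc1cc(C(=O)c2sc(-c3ccc(Cl)cc3)cc2N)cc(OC)c1OC`) gives 70 nM, and compound 2 (`COc1cc(C(=O)c2sc(-c3ccncc3)cc2N)cc(OC)c1OC`) gives 110 nM, so the two compounds sit within the scatter of each other. Compound 3 (`COc1cc(C(=O)c2sc(-c3ccc(C)cc3)cc2N)cc(OC)c1OC`) has 4-methylphenyl in place of the pyridin-4-yl of compound 2: 4-methylphenyl in place of pyridin-4-yl on an aromatic carbon. Among the compounds with values here, one measured step bears on this change, at the same place on the shared core: a 1.6-fold higher number from compound 1 to compound 2 (0.20 log units; within the scatter). That single small step gives no reason to expect a change beyond the scatter in this assay. The expected step is a 1.5-fold lower number from compound 2 to compound 3 (0.17 log units; within the scatter). For compound 3 the estimated value is 75 nM, with an expected range of 25 nM to 220 nM.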

Compound 3, half-maximal inhibitory concentration: 15 nM
For compound 3 the middle estimate is 5.0-fold (0.70 log units) above the measured one; measured number outside the range, below it.
By their numbers in this assay, from the lowest: compound 3; then compounds 1 and 2 (each within the scatter of the next).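

The group on the aromatic carbon next to the ring sulfur matters more than the earlier pair suggested: in this assay, 4-methylphenyl in place of pyridin-4-yl gives a 7.3-fold lower number from compound 2 to compound 3 (0.87 log units; beyond the scatter), a change beyond the scatter. Methyl in place of chloro gives a 4.7-fold lower number from compound 1 to compound 3 (0.67 log units; beyond the scatter), so changing only the group carried on the phenyl ring is enough to move the number beyond the scatter. Nothing measured here explains why compound 3 stands apart.

On these data alone, what a longer chain such as ethyl, or an amine, would give in place of that methyl remains open. So does the result for a plain phenyl ring carrying no added group.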